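Ketone to amide in a weak antiproliferative series

This account rests on a few compounds, and the source may have more. Where it says the series, first, only, none or still open, it means among the compounds named here.

Compound 1: `COc1cc(-c2nnc(SCC(=O)c3ccc(C)cc3)n2N)cc(OC)c1OC` — 31300 nM
Compound 2: `COc1cc(-c2nnc(SCC(=O)c3ccc(C(F)(F)F)cc3)n2N)cc(OC)c1OC` — > 100000 nM

In a functional assay on PC-3 cells (Homo sapiens) for antiproliferative activity, read by MTT assay, with a stated time of 48 h (a lower number here means a stronger inhibitor, a higher number a weaker inhibitor), compound 1 gives 31300 nM. This is the only number shown in this assay. Compound 2 is reported only as a limit of this assay, > 100000 nM, so its value is not a number; the step of an at least 3.1-fold higher number from compound 1 to compound 2 (0.50 log units; beyond the scatter) is therefore known only as a lower bound, and the limit of > 100000 nM in this assay, at which 1 of the 2 values shown sits, sets where it stops.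

Compound 3, `COc1cc(-c2nnc(SCC(=O)NCc3ccc(Cl)cc3)n2N)cc(OC)c1OC`, differs from compound 1 at the carbonyl carbon: (4-chlorobenzyl)amino in place of 4-methylphenyl on a carbonyl carbon. Among the measured compounds shown here, the change replaces a ketone with an amide bearing a halogenated benzyl group, so the only measured step, the exchange of trifluoromethyl for methyl on an aromatic carbon, concerns a different part of the molecule and does not bear on this change. For the measured compounds named here, no step in these data informs the direction. With compound 1 weak and compound 2 at the limit, compound 3 is expected to remain weak, near compound 1, with a step of about a 1.3-fold higher number from compound 1 to compound 3 (0.11 log units; within the scatter) expected. Compound 3 is estimated at 40000 nM, from 10000 nM to 150000 nM.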

Compound 3, half-maximal inhibitory concentration: > 100000 nM
Compound 3: a limit, no number; the forecaster's own chance of this, stated with the estimate: 35%; middle value at least 2.5-fold (0.39 log units) from the limit.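

In this assay, (4-chlorobenzyl)amino in place of 4-methylphenyl on the carbonyl carbon gives an at least 3.1-fold higher number from compound 1 to compound 3 (0.50 log units; beyond the scatter), so the exchange of the ketone for this amide does not hold activity at the already weak level of compound 1. Compound 3 is reported only as a limit, > 100000 nM, and not as a number. The earlier compounds showed a change only on the aromatic ring, whereas this result shows that a change at the carbonyl carbon can also take a compound out of the readable range, leaving the step between compound 2 and compound 3 unreadable and the true size of the loss unknown: the limit of > 100000 nM in this assay, at which 2 of the 3 values shown sit.

Whether the amide link or the 4-chlorobenzyl group accounts for the loss stays open, since the two enter together in compound 3. Also open, from the compounds shown here alone, is how a plain benzylamino group without the chlorine, or a simple phenyl ketone without the methyl group, would read against compound 1 in this assay.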